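A few compounds are considered here, and "the series" means these few. Any claim that something is new, unique, unknown or untested is made for them only; others in the source may bear on it.

Among the measured compounds shown here, in a functional assay on HeLa cells (Homo sapiens) for cytotoxicity, read by resazurin assay, with a stated time of 72 h (on this read-out higher numbers stand for weaker inhibition and lower numbers for stronger inhibition), compound 1 (`COc1cc(/C=C/C(=O)OCCCO[N+](=O)[O-])ccc1OCCCO[N+](=O)[O-]`) gives 3620 nM and compound 2 (`COc1cc(/C=C/C(=O)OCCCO[N+](=O)[O-])ccc1O`) gives 6700 nM as the only two measured values. These lie within the scatter of each other, so compound 1 stands level with compound 2. Compound 3 (`O=C(/C=C/c1ccc(OCCCO[N+](=O)[O-])c(O)c1)OCCCO[N+](=O)[O-]`) is still unmeasured. It differs from compound 1 by hydrogen in place of methyl on an oxygen on an aromatic ring in a single exchange, hydrogen in place of methyl on an oxygen on an aromatic ring, or methoxy to hydroxy. For the measured compounds named here, no measured step makes this same exchange. Going by the values given here, the only step that bears on it, a 1.9-fold higher number from compound 1 to compound 2 (0.27 log units; within the scatter) with hydrogen in place of 3-(nitrooxy)propyl on an oxygen on an aromatic ring, stays within the scatter, so no step beyond the scatter is expected in this assay here. The estimated step is a 1.2-fold higher number from compound 1 to compound 3 (0.09 log units; within the scatter) and would leave the numbers close together. Compound 3 is expected at 4500 nM within an estimated range of 2000 nM to 10000 nM on this read-out.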

Compound 3, half-maximal inhibitory concentration: > 50000 nM
Compound 3: a limit, no number; the forecaster's own chance of this, stated with the estimate: 3%; middle value at least 11-fold (1.04 log units) away from the limit.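

In this assay, methoxy to hydroxy, with hydrogen in place of methyl on an oxygen on an aromatic ring, gives an at least 13-fold higher number from compound 1 to compound 3 (1.14 log units; beyond the scatter). Compound 3 reads > 50000 nM, which is a limit of the assay and not a number: the limit of > 50000 nM in this assay, at which 1 of the 3 values shown sits. The only earlier change, hydrogen in place of 3-(nitrooxy)propyl on an oxygen on an aromatic ring, gave a 1.9-fold higher number from compound 1 to compound 2 (0.27 log units; within the scatter), so the methyl is the first place among these compounds where a single exchange moves the read-out beyond the scatter.

The compounds shown leave open how an ethoxy group or a longer chain on this oxygen would read, and whether an amine in place of the hydroxy would read like compound 3. They also leave open how far past its limit compound 3 lies.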